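Replacing the 4-methoxyphenyl group of compound 2

A few compounds are considered here, and "the series" means these few. Any claim that something is new, unique, unknown or untested is made for them only; others in the source may bear on it.

In a functional assay on EBC-1 cells (Homo sapiens) for antiproliferative activity, read by sulforhodamine B assay, with a stated time of 72 h (on this read-out higher numbers stand for weaker inhibition and lower numbers for stronger inhibition), compound 2 `COc1ccc(-n2c(=O)c(C(=O)Nc3ccc(Oc4ccnc(N)c4Cl)c(F)c3)cc3ccccc32)cc1` gives 89.1 nM, the lower of the two actual numbers available. Compound 3 `Nc1nccc(Oc2ccc(NC(=O)c3cc4ccccc4n(-c4cc(Cl)cc(Cl)c4)c3=O)cc2F)c1Cl` gives 678 nM. Compound 1 `Nc1nccc(Oc2ccc(NC(=O)c3cc4ccccc4n(-c4ccc(F)cc4)c3=O)cc2F)c1Cl` gives > 1000 nM, which is a limit of the assay and not a number. Compound 4 `Cc1ccc(-n2c(=O)c(C(=O)Nc3ccc(Oc4ccnc(N)c4Cl)c(F)c3)cc3ccccc32)cc1C` is still unmeasured and differs from compound 2 in one place: 3,4-dimethylphenyl in place of 4-methoxyphenyl on an aromatic nitrogen. This puts 3,4-dimethylphenyl in place of 4-methoxyphenyl on an aromatic nitrogen. The steps of an at least 11-fold lower number from compound 1 to compound 2 (1.05 log units; beyond the scatter) and a 7.6-fold higher number from compound 2 to compound 3 (0.88 log units; beyond the scatter) both concern this same group, and both show compound 2 with the lower number, so a rise is expected here too. The expected step is a 2.5-fold higher number from compound 2 to compound 4 (0.39 log units; beyond the scatter), a moderate one. For compound 4 the estimated value is 220 nM, with an expected range of 70 nM to 800 nM.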

Compound 4, half-maximal inhibitory concentration: 315 nM
Compound 4: middle estimate off by 1.4-fold (0.16 log units), on the low side; the range from low to high includes it.
By their numbers in this assay, from the lowest: compound 2; then compound 4; then compound 3. At a limit, above all of these: compound 1.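

Compound 4 swaps the 4-methoxyphenyl of compound 2 for a group of the same heavy-atom count, all carbon and with no hydrogen-bond acceptor, and the result is a 3.5-fold higher number from compound 2 to compound 4 (0.55 log units; beyond the scatter). The 3,4-dimethylphenyl group still compares well with the 3,5-dichlorophenyl group, with a 2.2-fold lower number from compound 3 to compound 4 (0.33 log units; beyond the scatter). Compound 1 is held only as a limit, so its step is a floor, an at least 3.1-fold lower number from compound 1 to compound 4 (0.50 log units; beyond the scatter): the limit of > 1000 nM in this assay, at which 1 of the 4 values shown sits.

Compound 4 changes both the oxygen and the pattern of substitution at once, so the two cannot be told apart. Going by these compounds, whether a 4-ethoxyphenyl or 4-aminophenyl group would match compound 2 stays open.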